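The source may report more compounds than this note shows. Statements on the series, on what has been measured and on what is new or still open speak of the compounds shown alone.

In an ADME assay on THP-1 cells (Homo sapiens) for cytotoxicity, read by trypan blue exclusion, with a stated time of 48 h (a lower number here means a stronger inhibitor of growth, a higher number a weaker inhibitor of growth), compound 1 (`Cc1cc(/C=N\OCc2ccccc2)c(C)n1-c1ccc(Cl)cc1`) gives 500 ug/mL and stands far from the other two measured compounds. Compound 2 (`Cc1cc(CNCc2ccc(F)cc2)c(C)n1-c1ccc(Cl)cc1`) gives 8.4 ug/mL and compound 3 (`Cc1cc(CNC2CCCCC2)c(C)n1-c1ccc(Cl)cc1`) gives 7.4 ug/mL as its value, so compound 3 sits level with compound 2 and far under compound 1.

Compound 4 (`Cc1cc(CNOCc2ccccc2)c(C)n1-c1ccc(Cl)cc1`) differs from compound 3 in one place: benzyloxy in place of cyclohexyl on an amine nitrogen. Within the data shown here, the one measured step that swaps a group on such a nitrogen, cyclohexyl in place of 4-fluorobenzyl, is a 1.1-fold lower number from compound 2 to compound 3 (0.06 log units; within the scatter) and so gives no sign of a change. Taken alone, that would point to no step beyond the scatter. However, compound 1 also carries benzyloxy, on a nitrogen that is not an amine nitrogen, and it has 500 ug/mL as its value. Among the measured compounds shown here, no measured compound has benzyloxy on an amine nitrogen, so neither clue settles the matter.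

A moderate move in this assay towards a higher number is therefore expected, staying well short of compound 1. The expected change is a 3.4-fold higher number from compound 3 to compound 4 (0.53 log units; beyond the scatter) and it remains only an estimate. The estimated value for compound 4 is 25 ug/mL with an expected range from 7 ug/mL to 150 ug/mL as the likely span.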

Compound 4, concentration for 50% growth inhibition: 67 ug/mL
Compound 4: middle estimate off by 2.7-fold (0.43 log units), on the low side; low and high end bracket the measured number.
By their numbers in this assay, from the lowest: compounds 3 and 2 (each within the scatter of the next); then compound 4; then compound 1.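

In this assay, a swap on an amine nitrogen had so far shown no sign of change, yet benzyloxy there gives a 9.1-fold higher number from compound 3 to compound 4 (0.96 log units; beyond the scatter) when it replaces cyclohexyl and an 8.0-fold higher number from compound 2 to compound 4 (0.90 log units; beyond the scatter) when it replaces 4-fluorobenzyl, so the group at this place can matter. Both steps point the same way, towards a weaker inhibitor of growth, and an aromatic ring alone does not set compound 4 apart, since compound 2 also carries one and its number stands level with that of compound 3. Nothing available here bears on why benzyloxy behaves differently from the other two groups.

The compounds shown leave open whether the oxygen of benzyloxy goes with the higher number, and a phenethyl group, which has a carbon in place of that oxygen, would speak to this directly. They also leave open whether a smaller group on the same oxygen, such as methoxy, would keep the higher number without any aromatic ring.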